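Trimming the Thiophene: From Compound 1 to Compound 3

The compounds below may be only part of what the source reports. "The series", "measured", "known", "first", "only" and "open" are said of these compounds alone.

Among the compounds with values here, compound 1 `Cc1cc(-c2nc3sc(C)cn3c2/C=N/NC(=N)N)c(C)s1` gives 15100 nM in a functional assay on cells (Melanoma cell, Homo sapiens) for inhibition (on this read-out higher numbers stand for weaker inhibition of growth and lower numbers for stronger inhibition of growth), the lowest of the two numbers known here, while compound 2 `Cc1cn2c(/C=N/Nc3ccccn3)c(-c3ccc(Cl)c([N+](=O)[O-])c3)nc2s1` gives 38000 nM, a number that lies beyond the scatter above it. Compound 3 `Cc1cn2c(/C=N/NC(=N)N)c(-c3ccsc3)nc2s1` differs from compound 1 by thiophen-3-yl in place of 2,5-dimethylthiophen-3-yl on an aromatic carbon. Within the data shown here, no measured pair here shows a change of this kind, so the size of the step is uncertain; the author expects a modest move toward weaker inhibition of growth, one that may not exceed the scatter. For compound 3 the estimate is 22000 nM, with a range from 8000 nM to 60000 nM, an expected step of a 1.5-fold higher number from compound 1 to compound 3 (0.16 log units; within the scatter).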

Compound 3, concentration for total growth inhibition: 19500 nM
Compound 3: middle estimate off by 1.1-fold (0.05 log units), on the high side; the range from low to high includes it.
By their numbers in this assay, from the lowest: compounds 1, 3 and 2 (each within the scatter of the next, the first and the last beyond it).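

Within the data shown here, replacing 2,5-dimethylthiophen-3-yl with thiophen-3-yl gives a 1.3-fold higher number from compound 1 to compound 3 (0.11 log units; within the scatter) in this assay and is the first step read at this position on the shared core. The two methyl groups can therefore be removed from the thiophene without a change that stands clear of the scatter on this read-out. Nothing measured here explains this result. Going by these compounds, it remains open whether a single methyl group on the thiophene would give a similar number. On these data alone, it is also open how an amine or a carboxylic acid on the thiophene would affect growth inhibition.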